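Furan to Thiophene Swap on a Nucleoside Core

The source may hold more compounds than are shown below. What is called first, only, known or untested is meant among the compounds shown, and "the series" means these compounds.

Compound 1, `O=c1[nH]cnc2c1c(-c1ccoc1)cn2[C@@H]1O[C@H](CO)[C@@H](O)[C@H]1O`, gives 14800 nM in a functional assay on HCT-116 cells (Homo sapiens), read by MTT assay, with a stated time of 72 h; on this read-out lower numbers stand for stronger inhibition and higher numbers for weaker inhibition.
Compound 2, `O=c1[nH]cnc2c1c(-c1cccs1)cn2[C@@H]1O[C@H](CO)[C@@H](O)[C@H]1O`, gives only a limit of the method in this assay, > 20000 nM.
Compound 3, `CSc1ncnc2c1c(-c1ccoc1)cn2[C@@H]1O[C@H](CO)[C@@H](O)[C@H]1O`, gives 100 nM in this assay.

Compound 3 stands lowest of these, and compound 1, the nearest with a number, sits far above it. How the core of compound 1 and the core of compound 3 differ is not broken down here. Compounds 1 and 2 differ by one change, (thiophen-2-yl in place of furan-3-yl on an aromatic carbon), and the step is an at least 1.3-fold higher number from compound 1 to compound 2 (0.13 log units; that floor lies within the scatter). Because compound 2 sits at the limit of > 20000 nM in this assay, at which 1 of the 3 values shown sits, only a floor for that step is known. Compound 4, `CSc1ncnc2c1c(-c1cccs1)cn2[C@@H]1O[C@H](CO)[C@@H](O)[C@H]1O`, has not yet been tested in this assay. It differs from compound 3 by thiophen-2-yl in place of furan-3-yl on an aromatic carbon, the same change as between compound 1 and compound 2, at a place described in identical words. Since the earlier step gave only a floor within the scatter, the step expected here is a 2.5-fold higher number from compound 3 to compound 4 (0.40 log units; beyond the scatter), and it rests on an at least 1.3-fold higher number from compound 1 to compound 2 (0.13 log units; that floor lies within the scatter). Compound 4 is therefore expected to give 250 nM in this assay, between 100 nM and 1000 nM.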

Compound 4, half-maximal inhibitory concentration: > 20000 nM
Compound 4: no number, only a limit; the forecaster's own chance of this, stated with the estimate: 3%; middle value at least 80-fold (1.90 log units) from the limit.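

In this assay, compound 4 gives only a limit of the method, > 20000 nM, and not a number. On the core of compound 3, thiophen-2-yl in place of furan-3-yl therefore gives an at least 200-fold higher number from compound 3 to compound 4 (2.30 log units; beyond the scatter), so this change removes nearly all of the strong inhibition seen with compound 3, and the true step may be larger still. The result does not show whether the change acts with the same size on both cores, since the earlier step is known only as a floor and the new one is also a floor: the same change on two cores in this assay, an at least 1.3-fold higher number (0.13 log units; that floor lies within the scatter) from compound 1 to compound 2 and an at least 200-fold higher number (2.30 log units; beyond the scatter) from compound 3 to compound 4; the limit leaves it open whether they differ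

As far as these compounds go, the true values of compound 2 and compound 4 remain unknown, as neither can be read past the limit of the method: the limit of > 20000 nM in this assay, at which 2 of the 4 values shown sit. The change also swaps the ring's hetero atom and its point of attachment together, so it remains open which of the two matters, a question that furan-2-yl or thiophen-3-yl on the same carbon of the core of compound 3 could answer.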